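Ring nitrogen substitution in a cell growth inhibition series

The source may report more compounds than this note shows. Statements on the series, on what has been measured and on what is new or still open speak of the compounds shown alone.

Measured so far, in a functional assay on NCI-H1975 cells (Homo sapiens) for inhibition, read by sulforhodamine B assay, tested at 10 uM; on this read-out higher numbers stand for more inhibition at the one concentration tested (going by the name of the read-out) and lower numbers for less inhibition:
compound 1 `CC(=O)N1N=C(c2ccc(N3CCN(C)CC3)cc2)CC1c1ccc(N(C)C)cc1` gives -1.9%
compound 2 `COC(=O)CC(=O)N1N=C(c2ccc(N3CCN(C)CC3)cc2)CC1c1ccc(N(C)C)cc1` gives -2.2%
compound 3 `COC(=O)CC(=O)N1N=C(c2ccc(-n3cncn3)cc2)CC1c1ccc(N(C)C)cc1` gives 1.5%

All three numbers sit near zero. The change a number 0.3 percentage points lower from compound 1 to compound 2 (within the scatter) and the change a number 3.7 percentage points higher from compound 2 to compound 3 (within the scatter) are both within the scatter, so compound 3, although nominally the largest of the three numbers, cannot be told apart from compound 1 or compound 2 on these data; the gap between compound 3 and compound 1 is also within the scatter.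

Compound 4 `CN(C)c1ccc(C2CC(c3ccc(-n4cncn4)cc3)=NN2S(=O)(=O)c2ccc(Br)cc2)cc1` is unmeasured. Against compound 3 it differs in one place: (4-bromophenyl)sulfonyl in place of ((methoxycarbonyl)methyl)carbonyl on an amine nitrogen in a ring. Within the data shown here, the one measured step touching this position is the one from compound 1 to compound 2, which also altered the group on the amine nitrogen in the ring and moved the read-out by a number 0.3 percentage points lower from compound 1 to compound 2 (within the scatter), within the scatter. The step from compound 2 to compound 3 lies elsewhere on the shared core and was likewise within the scatter. Among the measured compounds shown here, no measured step therefore points to a shift beyond the scatter, though the entering group is larger than anything exchanged so far, which widens the uncertainty.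

For compound 4 in this assay the expected value is 3%, in the range -9% to 18%. This expectation amounts to a step of a number 1.5 percentage points higher from compound 3 to compound 4 (within the scatter), i.e. none beyond the scatter.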

Compound 4, a percentage reported as inhibition, at one concentration (the size of the read-out at that concentration, not a potency): -0.6%
Beside the measured number, compound 4's estimate is 3.6 percentage points above it; low and high end bracket the measured number.
By their numbers in this assay, from the lowest: compounds 2, 1, 4 and 3 (each within the scatter of the next).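

On the amine nitrogen in the ring, (4-bromophenyl)sulfonyl in place of ((methoxycarbonyl)methyl)carbonyl gives, in this assay, a number 2.1 percentage points lower from compound 3 to compound 4 (within the scatter). The earlier step at this position exchanged only groups joined through a carbonyl, whereas this one brings in a sulfonyl link and a six-membered aromatic ring of carbon only, with 10 heavy atoms entering and 7 leaving, and compound 4 at -0.6% still cannot be told apart from compound 3. Nothing available bears on why this exchange leaves the read-out within the scatter.

Among these compounds, all four numbers sit near zero, so these compounds show only that the groups tried at this nitrogen give no separable read-out at the one concentration tested, and they leave open whether any group here can give a number beyond the scatter. Also open, as far as these compounds go, are a carboxylic acid or a chain ending in an amine on this nitrogen, a phenylsulfonyl group without the bromine, and whether (4-bromophenyl)sulfonyl would give the same result alongside 4-methylpiperazin-1-yl on the shared core.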